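The source may report more compounds than this note shows. Statements on the series, on what has been measured and on what is new or still open speak of the compounds shown alone.

Measured compounds and their maximal responses in a functional assay with Alpha-1A adrenergic receptor (Homo sapiens) as the target, read by calcium flux; on this read-out lower numbers stand for smaller maximal responses and higher numbers for larger maximal responses:
compound 1 `Cc1nc(-c2ccccc2NCC2=NCCN2)n(C)n1` gives 98%;
compound 2 `Cc1ccc(-c2ccccc2NCC2=NCCN2)n1C` gives 78%;
compound 3 `Cn1cccc1-c1ccccc1NCC1=NCCN1` gives 103%.

All three share one core, an aromatic six-membered carbon ring carrying a seven-heavy-atom side group, and differ only in the five-membered ring attached to that core. Compound 3 carries the largest of the three numbers, but compound 1 stands within the usual scatter of it, so those two cannot be told apart on this assay; only compound 2 sits clearly lower. For the measured compounds named here, the one directly comparable step is a number 25 percentage points higher from compound 2 to compound 3 (beyond the scatter), which came from a hydrogen in place of a methyl on an aromatic carbon of the five-membered ring.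

Compound 4 `Cc1n[nH]c(-c2ccccc2NCC2=NCCN2)n1` is not yet measured. Relative to compound 3 the change is 3-methyl-1H-1,2,4-triazol-5-yl in place of 1-methyl-1H-pyrrol-2-yl on an aromatic carbon. Going by the values given here, no measured step swaps one five-membered ring for another, so the step from compound 2 to compound 3 bears on it only loosely. The closest guide is compound 1, whose ring is also a methylated triazole and which gives a maximal response within the scatter of compound 3. Compound 4 is therefore expected to stay close to the higher values, with a step of a number 8 percentage points lower from compound 3 to compound 4 (within the scatter) that falls inside the scatter. The estimate for compound 4 is 95%, with a range from 75% to 110%.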

Compound 4, largest response reached (reported as maximal response), in percent of the reference or control that the assay uses: 87%
The estimate for compound 4 lay 8 percentage points above the measured number, within the range that was stated.
By their numbers in this assay, from the lowest: compounds 2 and 4 (each within the scatter of the next); then compounds 1 and 3 (each within the scatter of the next).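

In this assay, exchanging 1-methyl-1H-pyrrol-2-yl for 3-methyl-1H-1,2,4-triazol-5-yl on the aromatic carbon gives a number 16 percentage points lower from compound 3 to compound 4 (beyond the scatter), which shows that replacing one five-membered ring with another of the same 6 heavy atoms can change the maximal response by more than the scatter. The triazole ring alone does not settle the outcome: compound 1, which has a methyl on an aromatic nitrogen of that ring, stays within the scatter of compound 3, while hydrogen in place of that methyl gives a number 11 percentage points lower from compound 1 to compound 4 (beyond the scatter), so this one ring nitrogen position also matters. Nothing available explains why either step occurs.

From the compounds shown here alone, it remains open whether a longer chain on that ring nitrogen, such as an ethyl group, would hold the response near that of compound 1 or lower it further. Also unresolved is how the response would change if an amine or a carboxylic acid replaced the carbon-bound methyl on the triazole ring of compound 4.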